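Head-group swap on the chain end of compound 1

This account rests on a few compounds, and the source may have more. Where it says the series, first, only, none or still open, it means among the compounds named here.

Compound 1 `Cc1cc(-n2cc(C(=O)Nc3cc(F)cc(F)c3)c(=O)c3ccc(N(C)C)nc32)ccc1OCCCCCCC[N+]12CCN(CC1)CC2` and compound 2 `CN(C)c1ccc2c(=O)c(C(=O)Nc3cc(F)cc(F)c3)cn(-c3ccc(OCCCCCCC[N+]45CCN(CC4)CC5)c(Cl)c3)c2n1` share one core and differ in one place only. In an assay on LX2 cells for inhibition of COL1A1 promoter (Homo sapiens), read by a luciferase reporter, with a stated time of 24 h, tested at 50 uM (a higher number here means a stronger effect of the compound at the concentration tested, a lower number a weaker effect), compound 1 gives 20.8%, and in this assay compound 2 gives 20.5%; the step is a number 0.3 percentage points lower from compound 1 to compound 2 (within the scatter). Compound 1 thus holds the higher of the two numbers, yet its gap to compound 2 lies within the scatter, so the two read as equal.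

Compound 3 `Cc1cc(-n2cc(C(=O)Nc3cc(F)cc(F)c3)c(=O)c3ccc(N(C)C)nc32)ccc1OCCCCCCC[N+]1(C)CCCC1` is not yet measured. It differs from compound 1 by a group of 6 heavy atoms (5 carbon, 1 nitrogen; one five-membered non-aromatic ring with 1 hetero atom) in place of a group of 8 heavy atoms (6 carbon, 2 nitrogen; 2 six-membered non-aromatic rings with 2 hetero atoms each), on a saturated chain carbon, seven bonds along the chain from an oxygen on an aromatic ring. Among the compounds with values here, the single measured step, a number 0.3 percentage points lower from compound 1 to compound 2 (within the scatter), concerns a substituent on an aromatic carbon and not the charged group on the saturated chain carbon, so no measured step bears on this change. The expectation is therefore a number 0.8 percentage points lower from compound 1 to compound 3 (within the scatter), no step beyond the scatter. For compound 3 in this assay the estimate is 20%, with a range from 8% to 33%.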

Compound 3, a percentage reported as inhibition, at one concentration (the size of the read-out at that concentration, not a potency): 35.9%
Estimate against measurement, compound 3: 15.9 percentage points below; the measured number lies above the stated range.
By their numbers in this assay, from the lowest: compounds 2 and 1 (each within the scatter of the next); then compound 3.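

Working notes: the chain end is the first place in this series where a change moves the read-out. In this assay the swap gives a number 15.1 percentage points higher from compound 1 to compound 3 (beyond the scatter), whereas the change on the aromatic carbon gave a number 0.3 percentage points lower from compound 1 to compound 2 (within the scatter). The group of 6 heavy atoms and the group of 8 heavy atoms both carry a net charge of +1, so this step arises without a change in net charge, though they differ in ring size and in hydrogen-bond acceptors. No available evidence accounts for the step.

This single pair cannot separate the contributions of ring size, the second ring nitrogen and the hydrogen-bond acceptor. It also leaves open how an uncharged dimethylamino group or a longer chain would read, and whether the step persists with chloro in place of methyl on the aromatic carbon.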